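The compounds below may be only part of what the source reports. "The series", "measured", "known", "first", "only" and "open" are said of these compounds alone.

Measured in a functional assay on A549 cells (Homo sapiens) for cytotoxicity, read by MTT assay; on this read-out lower numbers stand for stronger inhibition and higher numbers for weaker inhibition:
Compound 1 `CCn1cc(C(=O)Nc2ccc(C)c([N+](=O)[O-])c2)c(=O)c2cc(F)c(N3CCNC(C)C3)c(F)c21`: 3700 nM
Compound 2 `CCn1cc(C(=O)Nc2cc([N+](=O)[O-])ccc2F)c(=O)c2cc(F)c(N3CCNC(C)C3)c(F)c21`: 1700 nM
Compound 3 `CCn1cc(C(=O)Nc2ccc(OC)cc2)c(=O)c2cc(F)c(N3CCNC(C)C3)c(F)c21`: 9700 nM

Of these three, compound 3 has the highest number, 9700 nM, and is therefore the weakest in this assay. The next compound, compound 4 `CCn1cc(C(=O)NCc2ccc(OC)cc2)c(=O)c2cc(F)c(N3CCNC(C)C3)c(F)c21`, has not yet been measured. It keeps the shared core and differs in one group, with 4-methoxybenzyl in place of 4-methoxyphenyl on an amide-type nitrogen.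

Within the data shown here, three measured steps concern this same nitrogen: a 2.2-fold lower number from compound 1 to compound 2 (0.34 log units; beyond the scatter), a 2.6-fold higher number from compound 1 to compound 3 (0.42 log units; beyond the scatter) and a 5.7-fold higher number from compound 2 to compound 3 (0.76 log units; beyond the scatter). All are modest, and all lie beyond the scatter. Each of them exchanges one substituted phenyl group for another, however, and none goes from a phenyl to a benzyl group. They therefore show how far the number has moved with changes at this place, but they do not give a direction for this change. No step beyond the scatter is expected, although a modest move either way remains possible, so the range is kept wide. The expected change is a 1.1-fold lower number from compound 3 to compound 4 (0.03 log units; within the scatter). For compound 4 the estimated value is 9000 nM, with an expected range from 3500 nM to 25000 nM.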

Compound 4, half-maximal inhibitory concentration: 7000 nM
Estimate against measurement, compound 4: 1.3-fold (0.11 log units) above; measured number inside the range.
By their numbers in this assay, from the lowest: compound 2; then compounds 1, 4 and 3 (each within the scatter of the next, the first and the last beyond it).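

In this assay, the first step from a phenyl to a benzyl group on this amide-type nitrogen (a 1.4-fold lower number from compound 3 to compound 4 (0.14 log units; within the scatter)) stays within the scatter, so going from (4-methoxyphenyl)amino to (4-methoxybenzyl)amino gives no readable change here. The 4-methoxybenzyl group also cannot be told apart from the 4-methyl-3-nitrophenyl group (a 1.9-fold higher number from compound 1 to compound 4 (0.28 log units; within the scatter)), even though the 4-methoxyphenyl and 4-methyl-3-nitrophenyl groups do differ beyond the scatter. Only the exchange from 2-fluoro-5-nitrophenyl (a 4.1-fold higher number from compound 2 to compound 4 (0.61 log units; beyond the scatter)) lies beyond the scatter, so among the groups compared with 4-methoxybenzyl, 2-fluoro-5-nitrophenyl alone stands apart from it.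

Nothing shown here gives a reason for these numbers. On these data alone, it remains open whether a benzyl group carrying the nitro and fluoro substituents of compound 2 would stay close to compound 2 or to compound 4, and how an unsubstituted benzyl group, a longer phenylethyl chain or a benzyl group bearing an amine or a carboxylic acid would behave on this nitrogen.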